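The compounds below may be only part of what the source reports. "The series", "measured", "known", "first", "only" and "open" are said of these compounds alone.

Measured so far:
- compound 1, `CC(C)N(C(=O)CN1C=CN(c2ccccc2)C(=O)C(Cc2n[nH]c3ccccc23)C1=O)c1ccc(F)cc1`: 50.1 nM
- compound 2, `O=C1[C@@H](Cc2n[nH]c3ccccc23)C(=O)N(c2ccccc2)C=CN1CC(=O)N1CCCCc2ccccc21`: 1.59 nM
- compound 3, `O=C1C(Cc2n[nH]c3cc(F)ccc23)C(=O)N(c2ccccc2)C=CN1CC(=O)N1CCCCc2ccccc21`: 1.59 nM

In a functional assay on CHO cells for agonist activity at Melanocyte-stimulating hormone receptor (Homo sapiens), read by a luciferase reporter, with a stated time of 4 h (a higher number here means that more compound is needed for the effect, a lower number that less compound is needed), compound 3 gives 1.59 nM. This puts compound 3 level with compound 2 at the digits printed, and together these two give the lowest numbers of the three; the gap to compound 1 is large and beyond the usual scatter.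

Compound 4, `O=C1C(Cc2n[nH]c3ccccc23)C(=O)N(c2ccccc2)C=CN1CC(=O)N1CCCCc2ccccc21`, has not yet been measured. It differs from compound 3 in one place only: hydrogen in place of fluoro on an aromatic carbon. Nothing else about the shared core or its side groups changes. Within the data shown here, no pair of measured compounds shows the effect of this single change, so the expectation rests on what the measured compounds show. Compound 2, which gives 1.59 nM in this assay, carries the same core and the same groups as compound 4 apart from the stereochemical notation, and its number is level with compound 3. On that basis the step from compound 3 to compound 4 is expected to be small, within the scatter, with no clear direction: a 1.0-fold higher number from compound 3 to compound 4 (0.00 log units; within the scatter). Compound 4 is therefore estimated at 1.6 nM in this assay, with a range from 0.6 nM to 4.5 nM.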

Compound 4, half-maximal effective concentration: 1.59 nM
Compound 4: middle estimate off by 1.0-fold (0.00 log units), on the high side, and the stated range covers the measured number.
By their numbers in this assay, from the lowest: compounds 2, 3 and 4 (each within the scatter of the next); then compound 1.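

In this assay, among these compounds, hydrogen can take the place of the fluoro group on this aromatic carbon with no change at the digits printed from compound 3 to compound 4 (within the scatter): this is the first direct reading of the change, and in this pair the fluorine is not needed for the low number. Among the compounds shown here, a second pair also stays level, with no change at the digits printed from compound 2 to compound 4 (within the scatter), and the only difference within that pair is this: the fact that one of compounds 2 and 4 is drawn with a defined configuration and the other without, at the place where they differ. A much larger shift appears when a group with a seven-membered non-aromatic ring replaces a fluorine-bearing group on a carbonyl carbon, with a 32-fold lower number from compound 1 to compound 4 (1.50 log units; beyond the scatter), so among these compounds that swap on the carbonyl carbon moves the number far more than the swap on the aromatic carbon does.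

The compounds shown carry only fluoro or hydrogen at this aromatic carbon, which leaves open what chloro, methoxy or an amine there would do. They also leave open how the S form at the stereocentre would read, and whether the form drawn without a configuration is a single form or a mixture.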